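This account rests on a few compounds, and the source may have more. Where it says the series, first, only, none or still open, it means among the compounds named here.

Of the compounds shown here, three of a shared core have been measured in an assay on membranes from liver for displacement of a labelled ligand from Glucagon receptor (Mus musculus), read by scintillation counting, with a stated time of 60 min; on this read-out higher numbers stand for weaker inhibition and lower numbers for stronger inhibition. Compound 1, `C[C@H](c1ccc(C(=O)NCCC(=O)O)cc1)N1C(=O)C(c2ccc(F)cc2)=N[C@]12CC[C@@H](C(C)(C)C)CC2`, gives 2500 nM. Within the data shown here, compound 3, `C[C@H](c1ccc(C(=O)NCCC(=O)O)cc1)N1C(=O)C(c2cccc(Cl)c2)=N[C@]12CC[C@@H](C(C)(C)C)CC2`, gives 3300 nM; the only step measured between two compounds that differ in one place, a 1.3-fold higher number from compound 1 to compound 3 (0.12 log units; within the scatter), shows that swapping one aromatic ring for another here changed little. Compound 2, `CCC[C@H](c1ccc(C(=O)NCc2nn[nH]n2)cc1)N1C(=O)C(c2cc(Cl)cc(Cl)c2)=N[C@]12CC[C@@H](C(C)(C)C)CC2`, gives 500 nM, the lowest number of the three and thus the strongest binder in this set, with compound 1 the nearest to it and compound 3 the furthest away.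

Compound 4, `CCCCC[C@H](c1ccc(C(=O)NCc2nn[nH]n2)cc1)N1C(=O)C(c2cc(Cl)cc(Cl)c2)=N[C@]12CC[C@@H](C(C)(C)C)CC2`, differs from compound 2 in a single place: ethyl in place of hydrogen on a saturated chain carbon, four bonds along the chain from an amide-type nitrogen in a ring and an aromatic carbon. Among the measured compounds shown here, no measured step bears on this change, since the one step available, a 1.3-fold higher number from compound 1 to compound 3 (0.12 log units; within the scatter), concerns the aromatic ring and not the chain, and the two other compounds both carry a methyl where compound 2 has a propyl and compound 4 a pentyl. The expectation for compound 4 therefore rests on compound 2 alone, and the step expected from compound 2 to compound 4 is a 1.3-fold higher number from compound 2 to compound 4 (0.11 log units; within the scatter), small and not clearly beyond the scatter in either direction. Compound 4 is thus estimated to give 650 nM in this assay, with a range from 200 nM to 2500 nM.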

Compound 4, half-maximal inhibitory concentration: 310 nM
Estimate against measurement, compound 4: 2.1-fold (0.32 log units) above; measured number inside the range.
By their numbers in this assay, from the lowest: compounds 4 and 2 (each within the scatter of the next); then compounds 1 and 3 (each within the scatter of the next).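

Among these compounds, the earlier compounds held no step at this position, and this is the first one: going from propyl to pentyl, with ethyl in place of hydrogen on the saturated chain carbon, gives a 1.6-fold lower number from compound 2 to compound 4 (0.21 log units; within the scatter) in this assay. Among the compounds shown here, the two compounds therefore cannot be told apart, which shows that at this position, with the rest of compound 2 unchanged, a chain with 2 more carbons is accepted without any measurable loss of binding; the earlier compounds could not show this, as their only step concerned the aromatic ring. Nothing measured here explains this tolerance of the longer chain.

The compounds shown leave open whether a still longer chain such as heptyl, or an amine or a carboxylic acid in place of the pentyl, would keep the number in the same range. On these data alone, compounds 1 and 3 carry a methyl at this carbon but also differ from compound 2 in other places, so what a much shorter chain does in the setting of compound 2 also remains open.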